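A few compounds are considered here, and "the series" means these few. Any claim that something is new, unique, unknown or untested is made for them only; others in the source may bear on it.

Three compounds built on the same core, a six-membered aromatic ring holding one nitrogen and carrying three aromatic groups, were tested in an assay on isolated protein for inhibition of DNA topoisomerase 1 (Homo sapiens), with a stated time of 30 min, tested at 20 uM; a higher number here means a stronger effect of the compound at the concentration tested, a lower number a weaker effect. Compound 1, with structure `Oc1ccccc1-c1cc(-c2ccco2)cc(-c2ccccc2O)n1`, gives 0.2% in this assay. Compound 2, with structure `Oc1cccc(-c2cc(-c3ccco3)cc(-c3ccccc3O)n2)c1`, gives 0% in this assay. Compound 3, with structure `Oc1cccc(-c2cc(-c3cccnc3)cc(-c3ccccc3O)n2)c1`, gives 0% in this assay. The change from compound 1 to compound 2 is 3-hydroxyphenyl in place of 2-hydroxyphenyl on an aromatic carbon, and it made a step of a number 0.2 percentage points lower from compound 1 to compound 2 (within the scatter). The change from compound 2 to compound 3 made a step of no change at the digits printed from compound 2 to compound 3 (within the scatter). The difference between the cores of compound 1 and compound 3 is not broken down here.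

Compound 4, with structure `Oc1cccc(-c2cc(-c3cccnc3)cc(-c3cccc(O)c3)n2)c1`, is not yet measured. It arises from compound 3 by 3-hydroxyphenyl in place of 2-hydroxyphenyl on an aromatic carbon. Going by the values given here, this is the same kind of change as the one from compound 1 to compound 2, though the surroundings differ: in the earlier case the place was meta to a 2-hydroxyphenyl group and meta to a furan-2-yl group, here it is meta to a 3-hydroxyphenyl group and meta to a pyridin-3-yl group. Because the earlier step was a number 0.2 percentage points lower from compound 1 to compound 2 (within the scatter), and because compound 3 sits at 0%, the same kind of change is expected to move compound 4 by about no change at the digits printed from compound 3 to compound 4 (within the scatter). Compound 4 is therefore expected to give about 0% in this assay, with a likely range from 0% to 8%.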

Compound 4, a percentage reported as inhibition, at one concentration (the size of the read-out at that concentration, not a potency): 1.9%
Compound 4: middle estimate off by 1.9 percentage points, on the low side; the measured number falls inside the stated range.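

On the core that carries pyridin-3-yl, putting 3-hydroxyphenyl in place of 2-hydroxyphenyl in this assay gave a number 1.9 percentage points higher from compound 3 to compound 4 (within the scatter). Set beside the same change on the core that carries furan-2-yl, this step shows that the two cores cannot be told apart in their response to the swap, so the change carries over as far as this read-out can show: the same change on two cores in this assay, a number 0.2 percentage points lower (within the scatter) from compound 1 to compound 2 and a number 1.9 percentage points higher (within the scatter) from compound 3 to compound 4, 2.1 percentage points apart, within the scatter of two such steps. This does not show that the position of the hydroxyl group is unimportant in general, since all four compounds give small readings at the single concentration tested, and a change that leaves a nearly silent compound nearly silent says little about what it would do to a compound with a clear effect.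

On these data alone, it remains open whether any compound on this core can give a clear inhibition in this assay, for instance with an amine or a carboxylic acid in place of the hydroxyl group on the outer rings, or with a longer chain in place of furan-2-yl or pyridin-3-yl. Also open, as far as these compounds go, is whether the same swap would give a step beyond the scatter on such a compound, which is the case that would truly test how well it carries from one core to another.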